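This account rests on a few compounds, and the source may have more. Where it says the series, first, only, none or still open, it means among the compounds named here.

Values in a physicochemical assay for solubility, using the shake flask method, measured as kinetic solubility, with a stated time of 20 h, at pH 2 (a higher number here means a more soluble compound, a lower number a less soluble compound), so far:
compound 1 `FC(F)(F)c1ccc(Nc2cc3[nH]c(C4CCOC4)nc3cn2)nc1` gives 200000 nM 
compound 2 `FC(F)(F)c1ccc(Nc2cc3[nH]c(C4CC4)nc3cn2)nc1` gives 198000 nM 
compound 3 `CC1(c2nc3cnc(Nc4ccc(C(F)(F)F)cn4)cc3[nH]2)CC1` gives 200000 nM 

Compound 3 at 200000 nM sits level with the other two compounds within the scatter. Compound 4 `FC(F)(F)c1ccc(Nc2cc3[nH]c(CC4CC4)nc3cn2)nc1` carries cyclopropylmethyl in place of 1-methylcyclopropyl on an aromatic carbon, between two ring nitrogen atoms, with cyclopropylmethyl in place of 1-methylcyclopropyl on an aromatic carbon as the counted difference. The closest measured evidence is a 1.0-fold higher number from compound 2 to compound 3 (0.00 log units; within the scatter) for methyl in place of hydrogen on a saturated ring carbon. Replacing oxolan-3-yl gave a 1.0-fold lower number from compound 1 to compound 2 (0.00 log units; within the scatter) for cyclopropyl and no change at the digits printed from compound 1 to compound 3 (within the scatter) for 1-methylcyclopropyl. All three steps lie within the scatter. Among the measured compounds shown here, no measured compound carries cyclopropylmethyl, so the expectation rests on analogy alone. No step beyond the scatter is expected in this assay for this change. The estimated move is a 1.1-fold lower number from compound 3 to compound 4 (0.02 log units; within the scatter) and stays within the scatter. For compound 4 the estimated value is 190000 nM with an expected range from 100000 nM to 210000 nM pending measurement.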

Compound 4, solubility: 186000 nM
The estimate for compound 4 lay 1.0-fold (0.01 log units) above the measured number; the range from low to high includes it.
By their numbers in this assay, from the lowest: compounds 4, 2, 1 and 3 (each within the scatter of the next).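

In this assay the same atoms joined differently, cyclopropylmethyl in place of 1-methylcyclopropyl on the aromatic carbon between two ring nitrogen atoms, give a 1.1-fold lower number from compound 3 to compound 4 (0.03 log units; within the scatter) as the step, so rearranging this group leaves the number within the scatter. Cyclopropylmethyl in place of cyclopropyl gives a 1.1-fold lower number from compound 2 to compound 4 (0.03 log units; within the scatter) and cyclopropylmethyl in place of oxolan-3-yl gives a 1.1-fold lower number from compound 1 to compound 4 (0.03 log units; within the scatter) as the other two steps, and all of them stay within the scatter, so compounds 1 to 4 cannot be separated at this position. No measurement shown here bears on why these numbers sit together.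

On these data alone, whether an amine, a carboxylic acid or a longer chain at this position would give a step beyond the scatter stays open. So does whether these four groups stay this close at another pH.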